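This account rests on a few compounds, and the source may have more. Where it says the series, first, only, none or still open, it means among the compounds named here.

Compound 2 `O=C(CCC1=CCN(CCCc2ccc(Cl)cc2)C1=O)NO` shares its core with compound 1 `O=C(CCC1=CCN(CCCc2ccc(Br)cc2)C1=O)NO` and compound 3 `CC(C)(C)c1ccc(CCCN2CC=C(CCC(=O)NO)C2=O)cc1`. In a functional assay on NCI-H23 cells (Homo sapiens) for inhibition, read by sulforhodamine B assay (a higher number here means a weaker inhibitor of growth, a lower number a stronger inhibitor of growth), compound 2 gives 2520 nM, compound 1 gives 2520 nM and compound 3 gives 2520 nM, so compound 2 stands level with both. Compound 4 `Cc1ccccc1CCCN1CC=C(CCC(=O)NO)C1=O` differs from compound 2 by 2-methylphenyl in place of 4-chlorophenyl on a saturated chain carbon, three bonds along the chain from an amide-type nitrogen in a ring. Among the measured compounds shown here, three measured steps bear on a swap of the group on that aromatic ring: no change at the digits printed from compound 1 to compound 2 (within the scatter), no change at the digits printed from compound 1 to compound 3 (within the scatter) and no change at the digits printed from compound 2 to compound 3 (within the scatter). None of them moved the reading in this assay, although none placed a methyl where it sits in 2-methylphenyl. Compound 4 is therefore expected to show no step beyond the scatter, no change at the digits printed from compound 2 to compound 4 (within the scatter). Compound 4 is estimated at 2520 nM in this assay, with a range from 1200 nM to 5300 nM.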

Compound 4, concentration for 50% growth inhibition: 2520 nM
The estimate for compound 4 equals the measured number at the digits printed; low and high end bracket the measured number.
By their numbers in this assay, from the lowest: compounds 1, 2, 3 and 4 (each within the scatter of the next).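

In this assay, the swap to 2-methylphenyl gives no change at the digits printed from compound 2 to compound 4 (within the scatter) and no change at the digits printed from compound 1 to compound 4 (within the scatter). Unlike the chloro, bromo and tert-butyl swaps, this change also moves the group's place on the aromatic ring, as the names 4-chlorophenyl and 2-methylphenyl show, and the reading still stays level. Nothing available accounts for this flat reading. From the compounds shown here alone, whether an amine or a carboxylic acid on the aromatic ring, or a longer chain carrying that ring, would move the reading remains open.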